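This account rests on a few compounds, and the source may have more. Where it says the series, first, only, none or still open, it means among the compounds named here.

In a functional assay on HeLa cells (Homo sapiens) for cytotoxicity, read by MTT assay, with a stated time of 48 h (on this read-out lower numbers stand for stronger inhibition and higher numbers for weaker inhibition), compound 1 `C=C1CCC[C@]2(C)CCC(c3cn(-c4ccccc4C(C)=O)nn3)=CC[C@@]12C` gives 55700 nM and compound 2 `C=C1CCC[C@]2(C)CCC(c3cn(CC(=O)Nc4ccc(C)cc4)nn3)=CC[C@@]12C` gives 131000 nM which is the higher of the two numbers. Compound 2 is therefore the weaker of this pair, by a gap beyond the usual scatter. Compound 3 `C=C1CCC[C@]2(C)CCC(c3cn(CC(=O)Nc4ccccc4)nn3)=CC[C@@]12C` differs from compound 2 in one place: hydrogen in place of methyl on an aromatic carbon with hydrogen in place of methyl on an aromatic carbon. Among the measured compounds shown here, no measured pair shows this change, so no step beyond the scatter is expected, and the estimated 1.1-fold lower number from compound 2 to compound 3 (0.06 log units; within the scatter) is small. For compound 3 the estimate is 115000 nM with an expected range from 50000 nM to 260000 nM as the likely span.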

Compound 3, half-maximal inhibitory concentration: 62900 nM
Compound 3: the middle estimate sits 1.8-fold (0.26 log units) above what was measured, within the range that was stated.
By their numbers in this assay, from the lowest: compounds 1 and 3 (each within the scatter of the next); then compound 2.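

Putting hydrogen in place of methyl, which turns the 4-methylphenyl group into phenyl, gives a 2.1-fold lower number from compound 2 to compound 3 (0.32 log units; beyond the scatter) in this assay. This modest step shows that the number responds to a change of a single carbon at this ring position, with the phenyl compound giving the lower number. Nothing available explains this shift.

On these data alone, what a chlorine atom, a methoxy group or an amine would do at this same position remains open. So does the effect of a longer chain there.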